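Extending the methylamino group on compound 3

The compounds below may be only part of what the source reports. "The series", "measured", "known", "first", "only" and "open" are said of these compounds alone.

Compound 1 `COc1cccnc1-c1cc(Cl)ccc1NS(=O)(=O)c1ccc(C(C)(C)C)cc1`: 958 nM
Compound 2 `CNc1ncc(O)c(-c2cc(Cl)ccc2NS(=O)(=O)c2ccc(C(C)(C)C)cc2)n1`: 27 nM
Compound 3 `CNc1nccnc1-c1cc(Cl)ccc1NS(=O)(=O)c1ccc(C(C)(C)C)cc1`: 25 nM

All three compounds were tested in a functional assay on isolated protein for antagonist activity at C-C chemokine receptor type 9 (Homo sapiens), read by calcium flux, with a stated time of 10 min; on this read-out higher numbers stand for weaker inhibition and lower numbers for stronger inhibition. Compound 3 gives the lowest number of the three. Its nearest neighbour is compound 2, and the step of a 1.1-fold lower number from compound 2 to compound 3 (0.03 log units; within the scatter) lies within the scatter, so no order can be claimed between these two. The furthest is compound 1, and the step of a 38-fold lower number from compound 1 to compound 3 (1.58 log units; beyond the scatter) is large and beyond the scatter, as is the step of a 35-fold lower number from compound 1 to compound 2 (1.55 log units; beyond the scatter).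

Compound 4 `CC(C)(C)c1ccc(S(=O)(=O)Nc2ccc(Cl)cc2-c2nccnc2NCCO)cc1` differs from compound 3 by hydroxymethyl in place of hydrogen on a saturated chain carbon bound to a nitrogen on an aromatic ring. Among the measured compounds shown here, none of the measured steps alters this part of the molecule: the steps from compound 1 replaced the whole aromatic ring, and the step between compound 2 and compound 3 removed a hydroxyl from the ring itself. The only hint is that this hydroxyl made no difference, since a 1.1-fold lower number from compound 2 to compound 3 (0.03 log units; within the scatter) stayed within the scatter. For the measured compounds named here, with no direct precedent, the expectation is a small step in this assay, none beyond the scatter, estimated as a 1.2-fold higher number from compound 3 to compound 4 (0.08 log units; within the scatter). Compound 4 is therefore expected to give about 30 nM in this assay, with a range from 10 nM to 90 nM.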

Compound 4, half-maximal inhibitory concentration: 34 nM
Estimate against measurement, compound 4: 1.1-fold (0.05 log units) below; the measured number falls inside the stated range.
By their numbers in this assay, from the lowest: compounds 3, 2 and 4 (each within the scatter of the next); then compound 1.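

In this assay, among the compounds shown here, the step of a 1.4-fold higher number from compound 3 to compound 4 (0.13 log units; within the scatter) is the first measured change at this position, and it stays within the scatter: on the saturated chain carbon bound to a nitrogen on an aromatic ring, hydroxymethyl in place of hydrogen, which turns methylamino into (2-hydroxyethyl)amino, gives no difference that this read-out can resolve. The step of a 1.3-fold higher number from compound 2 to compound 4 (0.10 log units; within the scatter) is also within the scatter, whereas the step of a 28-fold lower number from compound 1 to compound 4 (1.45 log units; beyond the scatter) remains large and beyond it, so compound 4 sits with compound 2 and compound 3, well apart from compound 1. No measurement shown offers an explanation for this result.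

The compounds shown leave open whether a longer chain such as 3-hydroxypropyl, or an amine or a carboxylic acid at the end of the chain in place of the hydroxyl, would keep the number in this range. Whether the hydroxyl itself counts, or only the added chain length, would take a comparison with an ethylamino group.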